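Lipophilicity notes: chain extension on the shared core

This account rests on a few compounds, and the source may have more. Where it says the series, first, only, none or still open, it means among the compounds named here.

Two members of the series have been measured in a physicochemical assay for lipophilicity; on this read-out higher numbers stand for higher lipophilicity and lower numbers for lower lipophilicity. Compound 1 `CCCCCCCCOc1ccc(-c2[nH]c3ccccc3c2C2=C(Br)C(=O)NC2=O)cc1` gives 5.21. Compound 2 `COc1ccc(-c2[nH]c3c(C)cccc3c2C2=C(Br)C(=O)NC2=O)cc1` gives 3.12, the lower of the two numbers on record; the gap to compound 1 is beyond the usual scatter, but compound 1 and compound 2 differ in more than one place, so only the two values themselves can be stated. Compound 3 `CCCc1cccc2c(C3=C(Br)C(=O)NC3=O)c(-c3ccc(OC)cc3)[nH]c12` has not yet been measured in this assay. It differs from compound 2 in one place, (ethyl in place of hydrogen on a saturated chain carbon bound to an aromatic carbon). For the measured compounds named here, no measured pair isolates this change. Growth of a saturated chain on this type of core is expected to raise the read-out by a moderate amount, beyond the scatter, and the step from a number 0.78 log units higher from compound 2 to compound 3 (beyond the scatter) is the estimated size of that rise. On this basis compound 3 is expected to give about 3.9, within the range 3.5 to 4.4.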

Compound 3, partition coefficient: 3.58
Estimate against measurement, compound 3: 0.32 log units above; the range from low to high includes it.
By their numbers in this assay, from the lowest: compound 2; then compound 3; then compound 1.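

For the compounds shown here, the change from hydrogen to ethyl on a saturated chain carbon bound to an aromatic carbon, which also reads as methyl to propyl, provides the first single-place comparison: in this assay it gives a number 0.46 log units higher from compound 2 to compound 3 (beyond the scatter). The read-out at this position therefore responds to chain growth, a point that could not be taken from compound 1 and compound 2, which differ in more than one place. No measurement on record accounts for the size of this step.

A single step cannot show whether a longer chain, such as hexyl, would continue the rise at this carbon or level off. From the compounds shown here alone, the effect on the read-out of an amine or a carboxylic acid at the end of the propyl chain also remains open.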